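From cyclohexyl to pyridin-3-yl on the side chain

The source may hold more compounds than are shown below. What is called first, only, known or untested is meant among the compounds shown, and "the series" means these compounds.

Compound 1 `Cc1ccc(/C=C/C[C@H]2C[C@@H]([C@@H](O)c3ccccc3)CO[C@@H]2c2ccccc2)cc1C` gives 9880 nM
Compound 2 `O[C@@H](c1ccccc1)[C@H]1CO[C@H](c2ccccc2)[C@@H](C/C=C/C2CCCCC2)C1` gives 6260 nM

In a functional assay on HL-60 cells (Homo sapiens) for cytotoxicity, read by WST assay, with a stated time of 48 h (on this read-out lower numbers stand for stronger inhibition and higher numbers for weaker inhibition), compound 2 stands at 6260 nM and compound 1 at 9880 nM, two numbers within the usual scatter of each other. Compound 3 `O[C@@H](c1ccccc1)[C@H]1CO[C@H](c2ccccc2)[C@@H](C/C=C/c2cccnc2)C1` has no number yet. It carries pyridin-3-yl in place of cyclohexyl on a double-bonded chain carbon bound to a double-bonded chain carbon. A six-membered non-aromatic ring of carbon only thus gives way to a six-membered aromatic ring with 1 hetero atom.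

For the measured compounds named here, only one measured step bears on this change: a 1.6-fold lower number from compound 1 to compound 2 (0.20 log units; within the scatter), with cyclohexyl in place of 3,4-dimethylphenyl on the same chain carbon. That step stayed within the scatter. Going by the values given here, a single step is thin evidence, however, and no measured compound carries a hetero atom in this group. No step beyond the scatter is therefore expected in this assay. The expected step is a 1.2-fold higher number from compound 2 to compound 3 (0.08 log units; within the scatter). For compound 3 the estimated value is 7500 nM, with an expected range from 3000 nM to 20000 nM.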

Compound 3, half-maximal inhibitory concentration: > 100000 nM
Compound 3 ended at the assay's limit (the forecaster's own chance of this, stated with the estimate: 5%); middle value at least 13-fold (1.12 log units) away from the limit.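

In this assay compound 3 gives > 100000 nM, which is a limit of the assay and not a number. Until now this position on the double-bonded chain carbon had held cyclohexyl and 3,4-dimethylphenyl with values within the scatter of each other, yet pyridin-3-yl gives an at least 15-fold higher number from compound 2 to compound 3 (1.20 log units; beyond the scatter) and an at least 10-fold higher number from compound 1 to compound 3 (1.00 log units; beyond the scatter), two steps well beyond the scatter. The position therefore does not take every six-membered ring alike, and an aromatic ring as such cannot be what separates them, since the 3,4-dimethylphenyl of compound 1 is aromatic too; among these three compounds, the clear difference belongs to the only ring with a nitrogen and a hydrogen-bond acceptor.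

On these data alone, the full size of both steps stays open because the value of compound 3 is a limit: the limit of > 100000 nM in this assay, at which 1 of the 3 values shown sits. Also open, as far as these compounds go, is whether the nitrogen alone accounts for the result, which unsubstituted phenyl, pyridin-4-yl or a cyclohexyl ring carrying an amine would help to settle.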